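A chloro group added to the far phenyl of compound 2

The source may hold more compounds than are shown below. What is called first, only, known or untested is meant among the compounds shown, and "the series" means these compounds.

Three pyrazoline compounds sharing one core have been tested in a functional assay on Caco-2 cells (Homo sapiens) for antiproliferative activity, read by MTT assay, with a stated time of 24 h; a lower number here means a stronger inhibitor, a higher number a weaker inhibitor. Compound 1 `Fc1ccc(C2CC(c3ccccc3)=NN2c2ccc(-c3ccccc3)nn2)cc1` gives 10000 nM. Compound 2 `FC(F)(F)c1ccc(C2CC(c3ccccc3)=NN2c2ccc(-c3ccccc3)nn2)cc1` gives 50000 nM, the highest of the two plain numbers; the step of a 5.0-fold higher number from compound 1 to compound 2 (0.70 log units; beyond the scatter) separates them. Compound 3 `COc1ccc(C2CC(c3ccccc3)=NN2c2ccc(-c3ccccc3)nn2)c(OC)c1` reaches only a limit of the assay, > 100000 nM, which is the limit of > 100000 nM in this assay, at which 1 of the 3 values shown sits. Its steps from the others, an at least 10-fold higher number from compound 1 to compound 3 (1.00 log units; beyond the scatter) and an at least 2.0-fold higher number from compound 2 to compound 3 (0.30 log units; that floor lies within the scatter), are therefore floors rather than exact sizes.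

Compound 4 `FC(F)(F)c1ccc(C2CC(c3ccc(Cl)cc3)=NN2c2ccc(-c3ccccc3)nn2)cc1` is not yet measured. It differs from compound 2 by chloro in place of hydrogen on an aromatic carbon. Going by the values given here, every measured step so far changed the aryl group on the saturated ring carbon; none touched the phenyl that now carries the chloro, so no measured step bears directly on this change. With nothing to point either way, the expectation for compound 4 in this assay is a step of no change at the digits printed from compound 2 to compound 4 (within the scatter) that stays within the scatter, giving an estimated value of 50000 nM, expected to lie between 15000 nM and 150000 nM.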

Compound 4, half-maximal inhibitory concentration: 10000 nM
Compound 4: the middle estimate sits 5.0-fold (0.70 log units) above what was measured, and the stated range ends above it.
By their numbers in this assay, from the lowest: compounds 1 and 4 (each within the scatter of the next); then compound 2. At a limit, above all of these: compound 3.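

In this assay, the phenyl on the far side of the shared core proves able to move the read-out: chloro in place of hydrogen, para to a large group, gives a 5.0-fold lower number from compound 2 to compound 4 (0.70 log units; beyond the scatter). Going by these compounds alone, every earlier step changed the aryl group on the saturated ring carbon, so this is the first sign that the other aryl group matters too, with a single chlorine atom lowering the number. The data shown give no reason for this step.

A single pair cannot show whether chloro would lower the number in the same way on the background of compound 1, which carries 4-fluorophenyl instead of 4-(trifluoromethyl)phenyl. Nor does it show whether this effect is particular to chloro, or whether an amine or a carboxylic acid at the same place would shift the number as well.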